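Methoxy addition and cytotoxicity in a small pyrazole-linked enone set

The source may hold more compounds than are shown below. What is called first, only, known or untested is meant among the compounds shown, and "the series" means these compounds.

Compound 3 `COc1ccc(-c2cc(/C=C/C(=O)c3ccc(N)cc3)[nH]n2)cc1OC` in a functional assay on Malme-3M cells (Homo sapiens) for cytotoxicity, read by sulforhodamine B assay, with a stated time of 48 h, tested at 1 uM (a lower number here means a stronger effect, a higher number a weaker effect of the compound at the concentration tested), gives 114%. Compound 1 `COc1cc(-c2cc(/C=C/C(=O)c3ccc(N)cc3)[nH]n2)cc(OC)c1OC` carries one more methoxy group, (methoxy in place of hydrogen on an aromatic carbon), and in this assay compound 1 gives 93%, so that a number 21 percentage points lower from compound 3 to compound 1 (beyond the scatter). Compound 2 `COc1ccc(C(=O)/C=C/c2cc(-c3cc(OC)c(OC)c(OC)c3)n[nH]2)cc1OC` in this assay gives 106%, with a number 13 percentage points higher from compound 1 to compound 2 (beyond the scatter); the difference between the cores of compound 2 and compound 3 is not broken down here. Compound 4 `COc1cc(C(=O)/C=C/c2cc(-c3cc(OC)c(OC)c(OC)c3)n[nH]2)cc(OC)c1OC` is not yet measured and differs from compound 2 by the same change, (methoxy in place of hydrogen on an aromatic carbon), the two place descriptions being the same word for word. Among the compounds with values here, for compound 4 a step of a number 18 percentage points lower from compound 2 to compound 4 (beyond the scatter) is expected because a number 21 percentage points lower from compound 3 to compound 1 (beyond the scatter) is the only precedent of this change. Compound 4 is therefore estimated at 88%, between 70% and 106%.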

Compound 4, a percentage reported as activity, at one concentration (the size of the read-out at that concentration, not a potency): 89%
Compound 4: middle estimate off by 1 percentage points, on the low side; the range from low to high includes it.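

In this assay, methoxy in place of hydrogen on an aromatic carbon gives a number 17 percentage points lower from compound 2 to compound 4 (beyond the scatter). The change carries across the two cores with a step of similar size: the same change on two cores in this assay, a number 21 percentage points lower (beyond the scatter) from compound 3 to compound 1 and a number 17 percentage points lower (beyond the scatter) from compound 2 to compound 4, 4 percentage points apart, within the scatter of two such steps. This rests on two pairs read at a single concentration, so it gives no potency and says nothing about cores other than these two.

The compounds shown leave open whether a group other than methoxy in this place, such as a hydroxy group, an amine or fluorine, would shift the read-out in the same way. Also open, as far as these compounds go, is whether a longer chain on the same oxygen, such as ethoxy, would keep a step of this size on both cores.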